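The source may report more compounds than this note shows. Statements on the series, on what has been measured and on what is new or still open speak of the compounds shown alone.

Compound 3 `Cc1ccc(N2CCN(C(=O)Nc3nc4ccc(F)cc4s3)CC2)nn1` stands at the limit of an assay on HEK293 cells for inhibition of transient receptor potential cation channel subfamily V member 1 (Homo sapiens), read by FLIPR, at pH 5.5; on this read-out lower numbers stand for stronger inhibition and higher numbers for weaker inhibition: in this assay compound 3 gives > 10000 nM, which is a limit rather than a number. Compound 1 `Cc1ccc(N2CCN(C(=O)Nc3ccc(C(C)C)cc3)CC2)nn1` likewise gives > 10000 nM, a limit. Compound 2 `Cc1ccc(N2CCN(C(=O)Nc3ccc(C(F)(F)F)cc3)CC2)nn1` gives > 10000 nM, also a limit. Going by the values given here, the only step between measured compounds, a step that the two limits leave unreadable from compound 1 to compound 2, is thus unreadable, and the limit of > 10000 nM in this assay, at which 3 of the 3 values shown sit, is all the evidence the series offers. Compound 4 `Cc1ccnnc1N1CCN(C(=O)Nc2nc3ccc(F)cc3s2)CC1` differs from compound 3 by 4-methylpyridazin-3-yl in place of 6-methylpyridazin-3-yl on an amine nitrogen in a ring. No measured step bears on this rearrangement, and no reason for any movement is at hand. Compound 4 is expected to sit near the limit as well, the estimated step that the limit leaves unreadable from compound 3 to compound 4 amounting to nothing beyond the scatter. The estimate for compound 4 is 20000 nM, ranging from 5000 nM to 80000 nM.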

Compound 4, half-maximal inhibitory concentration: > 25000 nM
Compound 4: a limit, no number (the forecaster's own chance of this, stated with the estimate: 80%); at least 1.2-fold (0.09 log units) between middle value and limit.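

In this assay compound 3 and compound 4 both give limits rather than numbers, and the step between them cannot be read. The compounds shown leave open whether either 6-methylpyridazin-3-yl or 4-methylpyridazin-3-yl on the shared core can give a measurable value in this assay.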